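A Methyl Group on the Aromatic Ring of Compound 3

This account rests on a few compounds, and the source may have more. Where it says the series, first, only, none or still open, it means among the compounds named here.

Of the compounds shown here, three have been tested in a functional assay on T47D cells (Homo sapiens) for inhibition, read by sulforhodamine B assay, with a stated time of 48 h; on this read-out lower numbers stand for stronger inhibition of growth and higher numbers for weaker inhibition of growth. Compound 1 `COC(=O)[C@@]1(C)CCC=C2[C@@H]1CC[C@@H](C)[C@]2(C)Cc1c(C)[nH]c2c(Br)cccc12` gives 31000 nM in this assay. Compound 2 `COC(=O)[C@@]1(C)CCC=C2[C@@H]1CC[C@@H](C)[C@]2(C)Cc1c(C)n(C(c2ccccc2)c2ccccc2)c2ccc(Cl)cc12` reaches only a limit of this assay, > 100000 nM. Compound 3 `COC(=O)[C@@]1(C)CC[C@@H]2C3=C1CC[C@@H](C)[C@]3(C)Cc1c2[nH]c2ccccc12` gives 3400 nM in this assay, the lowest of the two numbers obtained; the nearest number, that of compound 1, sits higher by a gap that lies beyond the usual scatter of repeated measurements.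

Compound 4 `COC(=O)[C@@]1(C)CC[C@@H]2C3=C1CC[C@@H](C)[C@]3(C)Cc1c2[nH]c2ccc(C)cc12` differs from compound 3 in a single place: methyl in place of hydrogen on an aromatic carbon. Within the data shown here, no measured pair shows the effect of such a change, so its size cannot be read from the numbers at hand. The expectation for this small addition is a step that stays within the scatter, with no firm direction. Compound 4 is therefore expected to give about 2800 nM in this assay, somewhere between 900 nM and 9000 nM. The expected step from compound 3 to compound 4 is a 1.2-fold lower number from compound 3 to compound 4 (0.08 log units; within the scatter).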

Compound 4, concentration for 50% growth inhibition: 16000 nM
Beside the measured number, compound 4's estimate is 5.7-fold (0.76 log units) below it; the measured number lies above the stated range.
By their numbers in this assay, from the lowest: compound 3; then compounds 4 and 1 (each within the scatter of the next). At a limit, above all of these: compound 2.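

In this assay, among these compounds, the first measured change at this aromatic carbon moves the number toward weaker inhibition of growth: methyl in place of hydrogen gives a clear step (a 4.7-fold higher number from compound 3 to compound 4 (0.67 log units; beyond the scatter)). The earlier compounds shown here could not show this, as no pair among them differed in one place. This carbon, meta to a fused ring and para to a fused ring, therefore does not tolerate every change without consequence, and even methyl moves the number beyond the scatter, although nothing measured here gives the reason for this step.

The compounds shown leave open whether fluorine, a methoxy group or an amine on this same carbon would raise the number as methyl does, or lower it. They also leave open whether a longer chain, such as ethyl, would take the number further in the same direction.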